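The source may hold more compounds than are shown below. What is called first, only, known or untested is meant among the compounds shown, and "the series" means these compounds.

Working notes on the series. Compound 1 `CC[C@H](C)[C@H](N)CN(C(=O)[C@@H]1C[C@H]1c1cccc(C)c1)c1ccc(-c2ccccc2)cc1` gives 1200 nM in a functional assay for agonist activity at G protein-coupled receptor 88 (Homo sapiens), read by HTRF and cAMP accumulation; on this read-out higher numbers stand for an effect only at larger amounts of compound and lower numbers for an effect already at smaller amounts. Compound 2 `CC[C@H](C)[C@H](N)CN(C(=O)[C@@H]1C[C@H]1c1cc(F)cc(F)c1)c1ccc(-c2ccccc2)cc1` gives 960 nM in this assay. Compound 3 `CC[C@H](C)[C@H](N)CN(C(=O)[C@@H]1C[C@H]1c1cccnc1)c1ccc(-c2ccccc2)cc1` gives 1500 nM in this assay, the largest of the three numbers shown, yet within the scatter of both others: a 1.3-fold higher number from compound 1 to compound 3 (0.10 log units; within the scatter) and a 1.6-fold higher number from compound 2 to compound 3 (0.19 log units; within the scatter); likewise a 1.3-fold lower number from compound 1 to compound 2 (0.10 log units; within the scatter). Compound 4 `CC[C@H](C)[C@H](N)CN(C(=O)[C@@H]1C[C@H]1c1ncccn1)c1ccc(-c2ccccc2)cc1` carries pyrimidin-2-yl in place of pyridin-3-yl on a saturated ring carbon. The three variations at this saturated ring carbon have so far moved this assay no further than the scatter, so for compound 4 no step beyond the scatter is expected, the estimated step being a 1.2-fold higher number from compound 3 to compound 4 (0.08 log units; within the scatter). Compound 4 is therefore expected to give 1800 nM in this assay, with a range from 800 nM to 4000 nM.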

Compound 4, half-maximal effective concentration: 130 nM
Estimate against measurement, compound 4: 14-fold (1.14 log units) above, outside the stated range (below it).
By their numbers in this assay, from the lowest: compound 4; then compounds 2, 1 and 3 (each within the scatter of the next).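

At this saturated ring carbon, the ring is not as indifferent in this assay as the earlier variations suggested: pyrimidin-2-yl separates from pyridin-3-yl with a 12-fold lower number from compound 3 to compound 4 (1.06 log units; beyond the scatter), and from the two substituted phenyl groups with a 7.4-fold lower number from compound 2 to compound 4 (0.87 log units; beyond the scatter) and a 9.2-fold lower number from compound 1 to compound 4 (0.97 log units; beyond the scatter). The ring keeps 6 heavy atoms in the step from compound 3, while its hetero atoms go from 1 to 2. Nothing available explains the size of this step.

On these data alone, it remains open whether the lower number is specific to pyrimidin-2-yl or extends to pyrimidin-5-yl or pyrazin-2-yl. Also open, as far as these compounds go, is whether it survives an added amine or methoxy group on the pyrimidin-2-yl ring.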